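The compounds below may be only part of what the source reports. "The series", "measured", "known", "first", "only" and "open" are said of these compounds alone.

Of the compounds shown here, three built on one shared core have been tested in a functional assay on A549 cells (Homo sapiens) for cytotoxicity, read by XTT assay, with a stated time of 72 h; on this read-out higher numbers stand for weaker inhibition and lower numbers for stronger inhibition. Compound 1 `CCn1ccc2cc(C(O)c3cc(OC)c(OC)c(OC)c3)ccc21` carries a hydroxy group on the carbon joining the two ring systems. For compound 1 the read-out in this assay is only a limit, > 10000 nM. Compound 2 `CCn1ccc2cc(C(OC(C)=O)c3cc(OC)c(OC)c(OC)c3)ccc21` differs from compound 1 by acetyl in place of hydrogen on an oxygen on a saturated carbon. For compound 2 this assay again returns only a limit, > 10000 nM. The step that the two limits leave unreadable from compound 1 to compound 2 therefore cannot be sized, since both ends sit at the limit (the limit of > 10000 nM in this assay, at which 3 of the 3 values shown sit).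

Compound 3 `CCn1ccc2cc(/C(=N\O)c3cc(OC)c(OC)c(OC)c3)ccc21` replaces that carbon centre with an oxime; the difference between its core and the core of compound 1 is not broken down here. For compound 3 this assay also gives only a limit, > 10000 nM.

Compound 4 `CCn1ccc2cc(/C(=N\OC(C)=O)c3cc(OC)c(OC)c(OC)c3)ccc21`, not yet measured, differs from compound 3 by acetyl in place of hydrogen on an oxygen. Going by the values given here, this is the same kind of change as the one from compound 1 to compound 2, but the place is not identical: in compound 1 the oxygen sits on a saturated carbon whose other neighbour is a saturated chain carbon, whereas in compound 3 the oxygen's other neighbour is a double-bonded nitrogen. Among the compounds with values here, since every value so far sits at the limit (the limit of > 10000 nM in this assay, at which 3 of the 3 values shown sit), the step that the limit leaves unreadable from compound 3 to compound 4 is expected to be unreadable in the same way. Compound 4 is accordingly estimated at 15000 nM, most probably reported again as a limit, with a plausible range from 4000 nM to 60000 nM.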

Compound 4, half-maximal inhibitory concentration: > 10000 nM
Compound 4 was reported as a limit (the forecaster's own chance of this, stated with the estimate: 85%); the middle value does not contradict the limit.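

In this assay compound 4 again gives only a limit, > 10000 nM. Compound 3 also stands at a limit, so the change from compound 3 to compound 4 cannot be sized, and no new step can be read: the limit of > 10000 nM in this assay, at which 4 of the 4 values shown sit.

The compounds shown leave open whether any change to the shared core would give a readable value in this assay.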